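This account rests on a few compounds, and the source may have more. Where it says the series, first, only, none or still open, it means among the compounds named here.

Working notes on the series. Going by the values given here, compound 1 `NC(=O)c1cnc2ccc(-c3cccnc3)cc2c1SC1CCCC1` gives in an assay on HT-29 cells for inhibition of Serine-protein kinase ATM (Homo sapiens), read by fluorescence, with a stated time of 1 h (a lower number here means a stronger inhibitor, a higher number a weaker inhibitor), a half-maximal inhibitory concentration of 9700 nM, the highest of the three numbers so far. Among the compounds with values here, compound 2 `CCC(CC)CNc1c(C(N)=O)cnc2ccc(-c3ccnnc3)cc12` gives 908 nM in this assay, and compound 3 `CCC(CC)CNc1c(C(N)=O)cnc2ccc(-c3ccc(CO)nc3)cc12` gives 87 nM; the one measured step, a 10-fold lower number from compound 2 to compound 3 (1.02 log units; beyond the scatter), changes the aryl group and not the position that distinguishes compound 4 from compound 1, so no measured step bears directly on the change at hand. Compound 4 `CCC(CC)COc1c(C(N)=O)cnc2ccc(-c3cccnc3)cc12` differs from compound 1 by 2-ethylbutoxy in place of cyclopentylsulfanyl on an aromatic carbon. Compounds 2 and 3 differ from compound 1 at both that position and the aryl group, so they give no clean comparison, though both lie far below compound 1. For compound 4 in this assay a moderate improvement over compound 1 is expected, a 4.9-fold lower number from compound 1 to compound 4 (0.69 log units; beyond the scatter), resting only on the open-chain substituents of compounds 2 and 3 reading lower. The estimate for compound 4 is 2000 nM, with a range from 500 nM to 8000 nM.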

Compound 4, half-maximal inhibitory concentration: > 30000 nM
Compound 4 gave a limit, no number; the forecaster's own chance of this, stated with the estimate: 3%; at least 15-fold (1.17 log units) between middle value and limit.
By their numbers in this assay, from the lowest: compound 3; then compound 2; then compound 1. At a limit, above all of these: compound 4.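

In this assay, going by these compounds alone, 2-ethylbutoxy in place of cyclopentylsulfanyl on the aromatic carbon ortho to a carbamoyl group gives an at least 3.0-fold higher number from compound 1 to compound 4 (0.49 log units; beyond the scatter), the first measured step at this position, and it shows that the number here responds strongly to the group at this position. Compound 4 reads as a limit of the assay and not as a number: the limit of > 30000 nM in this assay, at which 1 of the 4 values shown sits. The step is therefore a lower bound on the change, and it shows that an open chain on the core of compound 1 does not by itself lower the number.

The step changes the linking atom and replaces a ring with a chain in one move, so the compounds shown cannot separate the two changes. A cyclopentyloxy group or a cyclopentylamino group at this position, on the same core, would separate them.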